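Cyclohexyl for methoxyphenyl on a weakly antiproliferative lactam core

The source may hold more compounds than are shown below. What is called first, only, known or untested is meant among the compounds shown, and "the series" means these compounds.

Compound 1 `COc1cccc(N2C(=O)COc3ccc(-c4cccc(NS(=O)(=O)c5ccc(F)cc5)c4)cc32)c1`: > 40000 nM
Compound 2 `O=C1COc2ccc(-c3cnc(Cl)c(NS(=O)(=O)c4ccc(F)cc4)c3)cc2N1c1ccc(Cl)cc1`: 21600 nM

In a functional assay on A549 cells (Homo sapiens) for antiproliferative activity, read by MTT assay, with a stated time of 72 h (on this read-out lower numbers stand for stronger inhibition and higher numbers for weaker inhibition), compound 1 gives only a limit, > 40000 nM, so its true value is not known. Compound 2 gives 21600 nM in this assay. Compound 3 `O=C1COc2ccc(-c3cccc(NS(=O)(=O)c4ccc(F)cc4)c3)cc2N1C1CCCCC1` has not been measured; it differs from compound 1 by cyclohexyl in place of 3-methoxyphenyl on an amide-type nitrogen in a ring. Among the compounds with values here, with no measured step to guide it, the step from compound 1 to compound 3 is expected to be small or within the scatter, and compound 3 is estimated at 30000 nM (range 9000 nM to 60000 nM), corresponding to an expected at least 1.3-fold lower number from compound 1 to compound 3 (0.12 log units; that floor lies within the scatter).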

Compound 3, half-maximal inhibitory concentration: 14500 nM
For compound 3 the middle estimate is 2.1-fold (0.32 log units) above the measured one; low and high end bracket the measured number.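

In this assay, cyclohexyl in place of 3-methoxyphenyl on the amide-type nitrogen gives an at least 2.7-fold lower number from compound 1 to compound 3 (0.44 log units; beyond the scatter), so this position responds to the change, and an aromatic ring is not needed there for a measurable value. Because compound 1 stands at a limit, this step gives only a floor and its full size stays unknown: the limit of > 40000 nM in this assay, at which 1 of the 3 values shown sits.

Going by these compounds, it remains open whether plain phenyl would separate the effect of the ring from that of the methoxy group. On these data alone, it is also open how cyclopentyl, a longer alkyl chain or a ring carrying an amine would fare at this nitrogen.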